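The source may hold more compounds than are shown below. What is called first, only, known or untested is meant among the compounds shown, and "the series" means these compounds.

Three compounds were tested in a functional assay on SW480 cells (Homo sapiens) for cytotoxicity, read by MTT assay, with a stated time of 48 h; a lower number here means a stronger inhibitor, a higher number a weaker inhibitor. Compound 1 `C=CC(=C)[C@@H](O)C[C@H]1C(=C)CC[C@@H]2[C@]1(C)CCC[C@]2(C)C(=O)O` reaches only the limit of this assay, > 40000 nM. Compound 2 `C=C1CC[C@@H]2[C@](C)(CCC[C@]2(C)C(=O)O)[C@H]1CC/C(C)=C/CO` also stops at a limit, > 40000 nM. Compound 3 `C=CC(=C)CC[C@@H]1[C@@]2(C)CCC[C@](C)(COC(=O)/C=C\c3ccc(O)c(OC)c3)[C@@H]2CC[C@@]1(C)O` gives a number in this assay, 17600 nM. The step that the two limits leave unreadable from compound 1 to compound 2 cannot be sized because the limit of > 40000 nM in this assay, at which 2 of the 3 values shown sit, is where both of its values sit. Compound 2 therefore stands only at a limit among the values shown, and no number can be placed against it.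

Compound 4 `C=CC(=C)[C@H](O)C[C@H]1C(=C)CC[C@@H]2[C@]1(C)CCC[C@]2(C)C(=O)O` differs from compound 2 in one place: a group of 6 heavy atoms (5 carbon, 1 oxygen; no ring) in place of a group of 6 heavy atoms (5 carbon, 1 oxygen; no ring), on a saturated chain carbon bound to a saturated ring carbon. For the measured compounds named here, only the step from compound 1 to compound 2 bears on this change, and its size cannot be read. With no readable step to build on, no shift beyond the scatter is expected in this assay in either direction, and a limit is the likeliest outcome for compound 4. Compound 4 is estimated at 60000 nM, with a range from 20000 nM to 200000 nM. The step that the limit leaves unreadable from compound 2 to compound 4 that this estimate means is expected to lie within the scatter.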

Compound 4, half-maximal inhibitory concentration: > 40000 nM
Compound 4: a limit, no number; the forecaster's own chance of this, stated with the estimate: 80%; the middle value is on the limit's open side.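

Compound 4 stays at a limit in this assay, so its steps from compound 1 and from compound 2 cannot be read: the limit of > 40000 nM in this assay, at which 3 of the 4 values shown sit. Left open is whether the drawn configuration changes the result in this assay at all for compound 1 and compound 4: the fact that compounds 1 and 4 differ only in the configuration as drawn.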